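Trimming a Benzyl Side Chain in a Phthalimide Series

The source may report more compounds than this note shows. Statements on the series, on what has been measured and on what is new or still open speak of the compounds shown alone.

Compound 1 `CCOC(=O)C(Cc1ccccc1)ON1C(=O)c2ccccc2C1=O` shares its core with compound 2 `CCCC(C)ON1C(=O)c2ccccc2C1=O` and compound 3 `CC(C)OC(=O)C(C)ON1C(=O)c2ccccc2C1=O`. In a functional assay on the whole organism for inhibition, with Lepidium sativum as the target, tested at 1 ppm (a lower number here means less inhibition of growth, a higher number more inhibition of growth at the concentration tested), compound 1 gives 0%, level with compound 2 at 0%, and together these are the lowest numbers; compound 3 stands far higher at 51%. Among the measured compounds shown here, the single measured step, a number 51 percentage points higher from compound 2 to compound 3 (beyond the scatter), shows that an ester group on that chain carbon matters greatly. Compound 4 `CCOC(=O)C(CC)ON1C(=O)c2ccccc2C1=O` differs from compound 1 by methyl in place of phenyl on a saturated chain carbon, two bonds along the chain from a carbonyl carbon and an oxygen on an unsaturated carbon. For the measured compounds named here, no measured step covers this change directly, but compound 3, with a methyl on that carbon, shows much more inhibition than compound 1. A rise is therefore expected, a number 30 percentage points higher from compound 1 to compound 4 (beyond the scatter), and compound 4 is estimated at 30%, within 0% to 60%.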

Compound 4, percent growth inhibition at one concentration: 0%
For compound 4 the middle estimate is 30 percentage points above the measured one, within the range that was stated.
By their numbers in this assay, from the lowest: compounds 1, 2 and 4 (each within the scatter of the next); then compound 3.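

In this assay, methyl in place of phenyl on this saturated chain carbon, which cuts benzyl back to ethyl, gives no change at the digits printed from compound 1 to compound 4 (within the scatter) and so no gain in inhibition of growth. Losing the aromatic ring at this position is therefore not enough on its own to produce inhibition at the concentration tested while the ethyl ester stays in place. Nothing available explains this result.

Still open, from the compounds shown here alone, is whether an amine or a longer chain on this carbon would alter growth inhibition. A carboxylic acid in place of the ester also remains untested among the compounds shown.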